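Chain Length at the Carbinol Carbon of a Quinone Core

The compounds below may be only part of what the source reports. "The series", "measured", "known", "first", "only" and "open" are said of these compounds alone.

Compounds measured so far:
Compound 1, `COc1ccc(OC)c2c1C(=O)C=C(CO)C2=O`: 0.524 ug/mL
Compound 2, `CCCCCC(O)c1cc(OC)c2c(c1OC)C(=O)C=CC2=O`: 0.066 ug/mL
Compound 3, `COc1cc(C(C)O)c(OC)c2c1C(=O)C=CC2=O`: 0.132 ug/mL

In a functional assay on L1210 cells (Mus musculus) for cytotoxicity (a lower number here means that less compound is needed, a higher number that more compound is needed for the effect), compound 1 stands highest of the three numbers, so more of it is needed than of compound 2 or compound 3. Compound 3 sits nearest to compound 1, and compound 2 furthest, both gaps lying beyond the scatter.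

Compound 4, `COc1ccc(OC)c2c1C(=O)C=C(C(C)O)C2=O`, is not yet measured. It differs from compound 1 by methyl in place of hydrogen on a saturated chain carbon bound to a double-bonded ring carbon and an oxygen on a saturated carbon; cut one bond further out, the change reads hydroxymethyl to 1-hydroxyethyl.

Among the compounds with values here, one measured step bears on this. Between compound 2 and compound 3 the chain on the carbinol carbon shrinks from butyl to hydrogen, yet a 2.0-fold higher number from compound 2 to compound 3 (0.30 log units; within the scatter), so chain length at that carbon changed the number little. That step sits on the aromatic ring rather than on the quinone ring carbon of compound 1, so it guides only loosely. Still, the step is expected to be a 1.0-fold lower number from compound 1 to compound 4 (0.02 log units; within the scatter), with no direction beyond the scatter. Compound 4 is therefore estimated at 0.5 ug/mL, between 0.2 ug/mL and 1.2 ug/mL.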

Compound 4, concentration for half-maximal effect: 0.487 ug/mL
Beside the measured number, compound 4's estimate is 1.0-fold (0.01 log units) above it; low and high end bracket the measured number.
By their numbers in this assay, from the lowest: compounds 2 and 3 (each within the scatter of the next); then compounds 4 and 1 (each within the scatter of the next).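

In this assay, methyl in place of hydrogen on a saturated chain carbon bound to a double-bonded ring carbon and an oxygen on a saturated carbon gives a 1.1-fold lower number from compound 1 to compound 4 (0.03 log units; within the scatter) and so does not separate the two compounds. Within the data shown here, this is the first direct reading at this place, where the earlier step from butyl to hydrogen concerned a carbinol carbon on an aromatic carbon and could speak only indirectly. Hydroxymethyl and 1-hydroxyethyl thus cannot be told apart here, and nothing at hand gives a reason for this result.

On these data alone, whether butyl on this same chain carbon would also stay within the scatter remains open. So does the effect of an amine in place of the oxygen on that carbon.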